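This account rests on a few compounds, and the source may have more. Where it says the series, first, only, none or still open, it means among the compounds named here.

Working notes on the series. Three compounds share the core and have been run in an assay on isolated protein for inhibition of acid ceramidase (Homo sapiens), read by LC-MS, with a stated time of 1 h; a lower number here means a stronger inhibitor, a higher number a weaker inhibitor. Compound 1 `O=C(NCCCCc1ccccc1)n1c(-c2ccc(Cl)cc2)coc1=O` gives 5 nM in this assay. Compound 2 `CCCCCNC(=O)n1cc(-c2ccccc2)oc1=O` gives 39 nM. Compound 3 `COc1cccc(-c2cn(C(=O)NCCCCc3ccccc3)c(=O)o2)c1` gives 341 nM, the highest number of the three; its nearest neighbour is compound 2, and both gaps lie beyond the usual scatter, so compound 3 is the weakest inhibitor measured so far.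

The next compound, compound 4 `O=C(NCCCCc1ccccc1)n1cc(-c2cscn2)oc1=O`, keeps the phenylbutyl carbamoyl arm of compound 3 and changes only the aryl group on the core: 1,3-thiazol-4-yl in place of 3-methoxyphenyl on an aromatic carbon. Going by the values given here, no measured pair makes this same change, so the expected step rests on the spread of values seen rather than on a direct precedent. A moderate drop toward the range of compound 2 is expected, the estimated step being a 3.4-fold lower number from compound 3 to compound 4 (0.53 log units; beyond the scatter). Compound 4 is therefore expected to give about 100 nM in this assay, within roughly 30 nM to 400 nM.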

Compound 4, half-maximal inhibitory concentration: 44 nM
Estimate against measurement, compound 4: 2.3-fold (0.36 log units) above; low and high end bracket the measured number.
By their numbers in this assay, from the lowest: compound 1; then compounds 2 and 4 (each within the scatter of the next); then compound 3.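

In this assay, going by these compounds alone, with the phenylbutyl carbamoyl arm held fixed, swapping the aryl group next to the ring oxygen gives a 7.8-fold lower number from compound 3 to compound 4 (0.89 log units; beyond the scatter), the first single-place step. This position therefore responds to the group it carries, and a five-membered aromatic ring with 2 hetero atoms can replace a substituted six-membered one here without any loss. Nothing available explains this step.

The compounds shown leave open whether the step follows from the thiazole ring itself or from the loss of the methoxy group. On these data alone, how a thiophene or pyridine ring would compare at this position also remains open.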